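A few compounds are considered here, and "the series" means these few. Any claim that something is new, unique, unknown or untested is made for them only; others in the source may bear on it.

The series shares one core, seen in compound 1 `COc1cc(/C=C/C(=O)c2cccc(-n3cc(-c4ccc(Cl)cc4)[nH]c3=O)c2)ccc1O`, compound 2 `COc1cc(/C=C/C(=O)c2cccc(-n3cc(-c4ccccc4)[nH]c3=O)c2)cc(OC)c1OC` and compound 3 `O=C(/C=C/c1cccc(O)c1)c1cccc(-n2cc(-c3ccc(Cl)cc3)[nH]c2=O)c1`. In a functional assay on K562 cells (Homo sapiens) for inhibition (on this read-out higher numbers stand for weaker inhibition of growth and lower numbers for stronger inhibition of growth), compound 1 gives 1420 nM, compound 2 gives 500 nM and compound 3 gives 400 nM. Compound 2 thus holds the second highest of the three numbers: the gap to compound 3 lies within the scatter, while the gap to compound 1 lies beyond it. Within the data shown here, the one measured single-point step, a 3.6-fold lower number from compound 1 to compound 3 (0.55 log units; beyond the scatter), concerns the aryl on the double-bonded chain carbon, not the aromatic carbon of the five-membered ring.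

Compound 4 `COc1cc(/C=C/C(=O)c2cccc(-n3cc(-c4cc(OC)c(OC)c(OC)c4)[nH]c3=O)c2)cc(OC)c1OC` differs from compound 2 by 3,4,5-trimethoxyphenyl in place of phenyl on an aromatic carbon. Among the measured compounds shown here, no measured pair changes a group at this aromatic carbon, so the measured step gives no direct guide, and the size of the step in this assay is taken as none beyond the scatter, in either direction. The step for compound 4 is therefore expected as a 1.1-fold lower number from compound 2 to compound 4 (0.05 log units; within the scatter). In this assay compound 4 is estimated at 450 nM, within a range from 150 nM to 1400 nM.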

Compound 4, concentration for 50% growth inhibition: 590 nM
Compound 4: middle estimate off by 1.3-fold (0.12 log units), on the low side, and the stated range covers the measured number.
By their numbers in this assay, from the lowest: compounds 3, 2 and 4 (each within the scatter of the next); then compound 1.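

In this assay, among these compounds, the replacement gives a 1.2-fold higher number from compound 2 to compound 4 (0.07 log units; within the scatter) and so supplies the first measured change at this aromatic carbon of the five-membered aromatic ring, one that stays within the scatter. For this pair, phenyl with 6 heavy atoms and 0 hydrogen-bond acceptors and 3,4,5-trimethoxyphenyl with 12 heavy atoms and 3 hydrogen-bond acceptors cannot be told apart on this read-out, which contrasts with the step beyond the scatter seen at the aryl on the double-bonded chain carbon. No measurement at hand explains why the larger group leaves the number within the scatter.

As far as these compounds go, both members of this pair carry 3,4,5-trimethoxyphenyl on the double-bonded chain carbon, so whether the result holds with the 3-hydroxyphenyl of compound 3 stays open. Also open, from the compounds shown here alone, is how an amine or a carboxylic acid would read at this aromatic carbon in place of the aryl.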